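Phenyl to Methyl on the Ester: Expected Cytotoxicity Shift

The source may hold more compounds than are shown below. What is called first, only, known or untested is meant among the compounds shown, and "the series" means these compounds.

Three esters of one shared core have been tested in an ADME assay on HepG2 2.2.15 cells (Homo sapiens) for cytotoxicity, read by MTT assay; on this read-out lower numbers stand for higher toxicity in this test and higher numbers for lower toxicity in this test. Compound 1 `C=C1CC[C@@H]2[C@](C)(COC(=O)c3ccccc3)[C@H](O)CC[C@@]2(C)[C@@H]1C/C=C1\C=COC1=O` gives 82000 nM. Compound 2 `C=C1CC[C@@H]2[C@](C)(COC(C)=O)[C@H](O)CC[C@@]2(C)[C@@H]1C/C=C1\C=COC1=O` differs from it by methyl in place of phenyl on a carbonyl carbon, and compound 2 gives 334000 nM. Compound 3 `C=C1CC[C@@H]2[C@](C)(CO)[C@H](OC(=O)c3ccccc3)CC[C@@]2(C)[C@@H]1C/C=C1\C=COC1=O` has the same atoms as compound 1 joined differently; the difference between the two cores is not broken down here. In this assay compound 3 gives 103000 nM, a value within the usual scatter of compound 1. Compound 4 `C=C1CC[C@@H]2[C@](C)(CO)[C@H](OC(C)=O)CC[C@@]2(C)[C@@H]1C/C=C1\C=COC1=O` is not yet measured; it differs from compound 3 by methyl in place of phenyl on a carbonyl carbon, the same change at the same place that separates compound 1 from compound 2. Because the measured pair showed a 4.1-fold higher number from compound 1 to compound 2 (0.61 log units; beyond the scatter), a step of similar size is expected here, a 3.7-fold higher number from compound 3 to compound 4 (0.57 log units; beyond the scatter). Compound 4 is therefore estimated at 380000 nM, within 160000 nM to 850000 nM.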

Compound 4, half-maximal cytotoxic concentration: 872000 nM
Compound 4: the middle estimate sits 2.3-fold (0.36 log units) below what was measured; the whole stated range lies below it.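

In this assay, methyl in place of phenyl on a carbonyl carbon gives an 8.5-fold higher number from compound 3 to compound 4 (0.93 log units; beyond the scatter). Set beside the earlier step, the change runs the same way on both cores, and the two sizes cannot be told apart: the same change on two cores in this assay, a 4.1-fold higher number (0.61 log units; beyond the scatter) from compound 1 to compound 2 and an 8.5-fold higher number (0.93 log units; beyond the scatter) from compound 3 to compound 4, 2.1-fold (0.32 log units) apart, within the scatter of two such steps. Among these compounds, this suggests that the change carries over between these two cores, but it rests on only two pairs and shows neither why the number rises nor whether it would rise on a further core.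

As far as these compounds go, what a longer chain such as butyl, or a group carrying an amine, would do in place of methyl or phenyl on that carbonyl carbon stays open.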